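The source may hold more compounds than are shown below. What is called first, only, known or untested is meant among the compounds shown, and "the series" means these compounds.

Working notes on the series. Among the compounds with values here, in a functional assay on HL60/MX2 cells (Homo sapiens) for antiproliferative activity, read by MTT assay, with a stated time of 48 h (a higher number here means a weaker inhibitor, a lower number a stronger inhibitor), compound 3 `CN(C)CCCn1c(N)c(-c2nc3ccccc3[nH]2)c2nc(C#N)c(C#N)nc21` gives 2390 nM, the only true number so far. Compound 1 `CCn1c(N)c(-c2nc3ccccc3[nH]2)c2nc(C#N)c(C#N)nc21` reads > 50000 nM, which is a limit of the assay. Compound 2 `N#Cc1nc2c(-c3nc4ccccc4[nH]3)c(N)n(CCO)c2nc1C#N` reads > 50000 nM, also a limit. Three steps connect these compounds. The first, a step that the two limits leave unreadable from compound 1 to compound 2, cannot be sized. The other two, an at least 20-fold lower number from compound 1 to compound 3 (1.32 log units; beyond the scatter) and an at least 20-fold lower number from compound 2 to compound 3 (1.32 log units; beyond the scatter), are both large and beyond the scatter, and they set compound 3 apart from the other measured compounds.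

Next is compound 4 `N#Cc1nc2c(-c3nc4ccccc4[nH]3)c(N)n(CCCN3CCCCC3)c2nc1C#N`, with this change from compound 3: piperidin-1-yl in place of dimethylamino on a saturated chain carbon, three bonds along the chain from an aromatic nitrogen. In other words, 3-(dimethylamino)propyl becomes 3-(piperidin-1-yl)propyl. Neither large step exchanges one amine group for another, so their size does not carry over to this change. They bear on it only in that compound 4 keeps a nitrogen-bearing group at the chain end, the feature that separates compound 3 from the other two. Within the data shown here, compound 4 is therefore expected to stay near compound 3 in this assay, with no firm direction and no step clearly beyond the scatter. The expected outcome is a 1.2-fold lower number from compound 3 to compound 4 (0.08 log units; within the scatter). For compound 4 the estimated value is 2000 nM, with an expected range from 600 nM to 9000 nM.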

Compound 4, half-maximal inhibitory concentration: 1010 nM
Compound 4: middle estimate off by 2.0-fold (0.30 log units), on the high side; measured number inside the range.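

In this assay, piperidin-1-yl in place of dimethylamino on the saturated chain carbon gives a 2.4-fold lower number from compound 3 to compound 4 (0.37 log units; beyond the scatter). Within the data shown here, this is the first step between two true numbers, and it shows that the amine group at the end of the chain can be exchanged with a readable change beyond the scatter, here in favour of the six-membered non-aromatic ring. Compound 3 is no longer alone in standing apart from the chains without an amine, with an at least 49-fold lower number from compound 2 to compound 4 (1.69 log units; beyond the scatter) and an at least 49-fold lower number from compound 1 to compound 4 (1.69 log units; beyond the scatter), but both of these steps start from compound 2 and compound 1, which each stand at a limit and not at a number: the limit of > 50000 nM in this assay, at which 2 of the 4 values shown sit.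

Only dimethylamino and piperidin-1-yl are shown at this position, so it remains open whether a morpholine, a piperazine or an unsubstituted primary amine at the chain end would follow the step seen for compound 4. Also open, as far as these compounds go, is how the value would respond to a shorter or longer chain carrying the same piperidin-1-yl group, such as 2-(piperidin-1-yl)ethyl.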